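Leaving the 6-(methanesulfonamido)pyridin-3-yl group: notes on the series

The source may hold more compounds than are shown below. What is called first, only, known or untested is meant among the compounds shown, and "the series" means these compounds.

In a functional assay on K562 cells (Homo sapiens) for inhibition, read by MTT assay, with a stated time of 48 h (on this read-out higher numbers stand for weaker inhibition and lower numbers for stronger inhibition), compound 1 `Nc1ccc(-c2cn([C@@H]3CN[C@H](C(=O)Nc4ccc(Cl)c(C(F)(F)F)c4)C3)nn2)cn1` gives 10400 nM, compound 2 `O=C(Nc1ccc(-c2cn([C@@H]3CN[C@H](C(=O)Nc4ccc(Cl)c(C(F)(F)F)c4)C3)nn2)cn1)C1CC1` gives 8770 nM and compound 3 `CS(=O)(=O)Nc1ccc(-c2cn([C@@H]3CN[C@H](C(=O)Nc4ccc(Cl)c(C(F)(F)F)c4)C3)nn2)cn1` gives 5060 nM. Compound 3 separates from compound 1 only, with a 2.1-fold lower number from compound 1 to compound 3 (0.31 log units; beyond the scatter), a modest step. Its neighbour is compound 2, with a 1.7-fold lower number from compound 2 to compound 3 (0.24 log units; within the scatter), and a 1.2-fold lower number from compound 1 to compound 2 (0.07 log units; within the scatter) closes the set.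

Compound 4 `O=C(NC1CC1)c1cncc(-c2cn([C@@H]3CN[C@H](C(=O)Nc4ccc(Cl)c(C(F)(F)F)c4)C3)nn2)c1` carries 5-(cyclopropylcarbamoyl)pyridin-3-yl in place of 6-(methanesulfonamido)pyridin-3-yl on an aromatic carbon. The measured steps change only the group on a nitrogen on an aromatic ring, and none tests this replacement directly. The nearest guide is compound 2, which also lacks methylsulfonyl and carries a cyclopropyl-bearing group, at 8770 nM. All three measured values lie close together, so no step beyond the scatter is expected in this assay, with a slight lean towards a higher number.

The estimated step is a 1.4-fold higher number from compound 3 to compound 4 (0.14 log units; within the scatter). Compound 4 is estimated at 7000 nM, with an expected range from 3000 nM to 16000 nM.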

Compound 4, half-maximal inhibitory concentration: 820 nM
Compound 4: the middle estimate sits 8.5-fold (0.93 log units) above what was measured; measured number outside the range, below it.
By their numbers in this assay, from the lowest: compound 4; then compounds 3, 2 and 1 (each within the scatter of the next, the first and the last beyond it).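

Changes on the nitrogen of the aminopyridine left the numbers close together, whereas replacing the whole group on this aromatic carbon gives the first clear movement in this assay, with a 6.2-fold lower number from compound 3 to compound 4 (0.79 log units; beyond the scatter), an 11-fold lower number from compound 2 to compound 4 (1.03 log units; beyond the scatter) and a 13-fold lower number from compound 1 to compound 4 (1.10 log units; beyond the scatter). Compound 2 also carries a cyclopropyl group, so that ring alone does not go with the lower number; what separates compound 4 from compound 2 is the whole 5-(cyclopropylcarbamoyl)pyridin-3-yl group. Nothing at hand gives a cause for these steps.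

Still open, as far as these compounds go, is whether the step follows the cyclopropyl ring, the reversed amide or the placement on the pyridine. A 6-(cyclopropylcarbamoyl)pyridin-3-yl group and a plain 5-carbamoylpyridin-3-yl group would separate these, and a 5-carboxypyridin-3-yl group would test whether the amide nitrogen is needed at all.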